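The source may report more compounds than this note shows. Statements on the series, on what has been measured and on what is new or still open speak of the compounds shown alone.

Compound 1 `Cc1ccccc1Nc1nc(NC2CC2)ncc1Cl` and compound 2 `Cc1ccccc1Nc1nc(Nc2ccccc2)ncc1Cl` share the same core and differ only at the group carried on one ring nitrogen. In a functional assay on MDA-MB-231 cells (Homo sapiens) for inhibition, read by CCK-8 assay, with a stated time of 48 h (a lower number here means a stronger inhibitor of growth, a higher number a weaker inhibitor of growth), compound 1 gives only a limit, > 100000 nM. In this assay compound 2 likewise gives only a limit, > 100000 nM. The step that the two limits leave unreadable from compound 1 to compound 2 is therefore unreadable, and compound 2 simply stands at the limit of > 100000 nM in this assay, at which 2 of the 2 values shown sit. Compound 3 `Cc1ccccc1Nc1nc(Nc2ccc(N3CCCN(C)CC3)cc2)ncc1Cl` differs from compound 2 by 4-methyl-1,4-diazepan-1-yl in place of hydrogen on an aromatic carbon. No measured step bears on this change: the single step measured, the exchange of cyclopropyl for phenyl, gives no readable size, so nothing in the numbers shown points to a direction. The step of an at least 3.3-fold lower number from compound 2 to compound 3 (0.52 log units; beyond the scatter) is thus an estimate made without any anchor from the measured pair. The estimate for compound 3 in this assay is 30000 nM, expected to fall between 3000 nM and 200000 nM.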

Compound 3, concentration for 50% growth inhibition: 6390 nM
Compound 3: middle estimate off by 4.7-fold (0.67 log units), on the high side, within the range that was stated.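

Among the compounds shown here, compound 3 is the first compound here to leave the ceiling of this assay, where the earlier values are only limits: the limit of > 100000 nM in this assay, at which 2 of the 3 values shown sit. Placing 4-methyl-1,4-diazepan-1-yl on an aromatic carbon of the six-membered aromatic ring of carbon only, para to a large group, gives an at least 15-fold lower number from compound 2 to compound 3 (1.19 log units; beyond the scatter). As far as these compounds go, this shows that growth inhibition can respond to a change at this position, and the true size of the step remains unknown since one end of it is a limit.

The compounds shown leave open whether the seven-membered ring is required, or whether a piperazine, a morpholine or a simple dimethylamino group on the same aromatic carbon would serve as well. They also leave open what the methyl on the diazepane nitrogen contributes, since a hydrogen or an ethyl group there could give a different number.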